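Swapping the sulfonyl aryl group in a stability series

The source may hold more compounds than are shown below. What is called first, only, known or untested is meant among the compounds shown, and "the series" means these compounds.

Three compounds share a common core, and two of them have a number in an ADME assay on microsomes from liver (Homo sapiens) for metabolic stability, with a stated time of 30 min, tested at 1 uM; on this read-out lower numbers stand for a less stable compound and higher numbers for a more stable compound. Compound 1 `CN(Cc1ccc(C2=NCCN2)cc1)C(=O)COCCN(C)S(=O)(=O)c1ccccc1C#N` gives 87% in this assay. Compound 3 `Cc1c(Cl)ccc(S(=O)(=O)N(C)CC(=O)NCC(=O)N(C)Cc2ccc(C3=NCCN3)cc2)c1Cl` gives 2% in this assay. Going by the values given here, the two values show a very wide gap, but no step between them is described here, so the comparison is left at what the two numbers show.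

Compound 2 `CN(Cc1ccc(C2=NCCN2)cc1)C(=O)COCCN(C)S(=O)(=O)c1c(Cl)cccc1Cl` has "not determined" (no result reported) in this assay, that is, no result; its position among the measured compounds is therefore unknown, and it can be placed neither near compound 1 nor near compound 3.

Compound 4 `COc1cc(C)c(S(=O)(=O)N(C)CCOCC(=O)N(C)Cc2ccc(C3=NCCN3)cc2)c(C)c1` is drawn from compound 2 by one change: 4-methoxy-2,6-dimethylphenyl in place of 2,6-dichlorophenyl on a sulfonyl sulfur. Among the compounds with values here, since compound 2 has no number in this assay and no step between any two measured compounds is described, there is no basis for saying how large this change would be, or in which direction, beyond the scatter.

The expectation for compound 4 can rest only on the measured spread, which runs from compound 3 to compound 1. Compound 4 is therefore estimated at 40% in this assay, with a wide band from 5% to 85%.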

Compound 4, percent of the compound remaining: 57%
Estimate against measurement, compound 4: 17 percentage points below; the measured number falls inside the stated range.
By their numbers in this assay, from the lowest: compound 3; then compound 4; then compound 1.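

The sulfonyl aryl group now has its first readable step: in this assay, with the rest of the molecule unchanged, 4-methoxy-2,6-dimethylphenyl in place of 2-cyanophenyl on a sulfonyl sulfur gives a number 30 percentage points lower from compound 1 to compound 4 (beyond the scatter), so exchanging this one group is enough to move the read-out past the usual scatter. As far as these compounds go, the comparison between compound 2 and compound 4 cannot be read, since compound 2 has no number, and the standing of the 2,6-dichlorophenyl group at this position therefore remains unknown. This single step records how much the read-out moves, but no measurement shown here gives a reason for the size or direction of that shift.

The two aryl groups in the readable step differ in more than one substituent, so the compounds shown cannot tell whether the nitrile, the methoxy group or the two methyl groups account for the change. From the compounds shown here alone, how a plain phenyl, a 2,6-dimethylphenyl without the methoxy group or a pyridine ring would compare at this sulfonyl sulfur also remains open, and any of these could help separate those contributions.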